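3,4-Dichlorophenyl to 3-(trifluoromethyl)phenyl: an expected drop

The source may report more compounds than this note shows. Statements on the series, on what has been measured and on what is new or still open speak of the compounds shown alone.

Of the compounds shown here, three sharing one core have been measured in a functional assay on KM12 cells (Homo sapiens) for inhibition, read by sulforhodamine B assay, with a stated time of 48 h, tested at 1 uM; on this read-out lower numbers stand for a stronger effect and higher numbers for a weaker effect at the one concentration tested. Compound 3 `COc1cc(Cl)cc(-c2nn(-c3cccc(NC(=O)Nc4ccc(Cl)c(Cl)c4)c3)cc2-c2ccncc2)c1` gives 72%, the highest number of the three, which on this read-out means the weakest effect. Compound 1 `COc1cc(Cl)cc(-c2nn(-c3cccc(NC(=O)Nc4ccc(Cl)c(C(F)(F)F)c4)c3)cc2-c2ccncc2)c1` gives 33% in this assay, and compound 2 `COc1cc(Cl)cc(-c2nn(-c3cccc(NC(=O)Nc4cc(C(F)(F)F)cc(C(F)(F)F)c4)c3)cc2-c2ccncc2)c1` gives 31%. Among the compounds with values here, the single one-place step among them, a number 39 percentage points higher from compound 1 to compound 3 (beyond the scatter), shows that removing a trifluoromethyl in favour of a chloro weakened the effect considerably.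

Compound 4 `COc1cc(Cl)cc(-c2nn(-c3cccc(NC(=O)Nc4cccc(C(F)(F)F)c4)c3)cc2-c2ccncc2)c1` is not yet measured. It differs from compound 3 in one place: 3-(trifluoromethyl)phenyl in place of 3,4-dichlorophenyl on an amide-type nitrogen. The change runs opposite to the measured step, since a trifluoromethyl returns and a chloro is lost; compound 1 and compound 2, which both carry a trifluoromethyl on that ring, sit far below compound 3 in this assay. The step from compound 1 to compound 3 therefore bears directly on this change, and a drop of roughly the same size, well beyond the scatter, is expected for compound 4, though compound 4 carries one substituent where compound 1 carries two. The expected step is a number 34 percentage points lower from compound 3 to compound 4 (beyond the scatter). For compound 4 in this assay the estimate is 38%, with a range from 22% to 58%.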

Compound 4, a percentage reported as activity, at one concentration (the size of the read-out at that concentration, not a potency): 38%
Compound 4: the middle estimate sits on the measured number at the digits printed; the measured number falls inside the stated range.
By their numbers in this assay, from the lowest: compounds 2, 1 and 4 (each within the scatter of the next); then compound 3.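

In this assay, replacing 3,4-dichlorophenyl with 3-(trifluoromethyl)phenyl on the amide-type nitrogen gives a number 34 percentage points lower from compound 3 to compound 4 (beyond the scatter) and so shows that this one swap is enough for a large step, with no second substituent on the ring needed. Hydrogen in place of chloro gives a number 5 percentage points higher from compound 1 to compound 4 (within the scatter) and hydrogen in place of the second trifluoromethyl gives a number 7 percentage points higher from compound 2 to compound 4 (within the scatter), so neither extra group makes a difference that can be told from the scatter at the one concentration tested. Among these four compounds, a chloro on this ring goes with a low number when a trifluoromethyl is also there, as in compound 1, while compound 3, the only one with no trifluoromethyl, stands apart.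

As far as these compounds go, it remains open whether a nitrile, an amine or a carboxylic acid in the place of this trifluoromethyl would keep the number near that of compound 4, or whether a ring carrying only hydrogens would do the same. Nothing measured here gives a reason why trifluoromethyl and chloro differ on this ring.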